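Nitrile-bearing indole in a P2X7 antagonist series

This account rests on a few compounds, and the source may have more. Where it says the series, first, only, none or still open, it means among the compounds named here.

Measured so far:
compound 1, `O=c1[nH]c2ccccc2n1CCCCCN1CCN(C(c2ccccc2)c2ccccc2)CC1`, 560 nM
compound 2, `Cc1cccc2c1ccn2CCCCN1CCN(C(c2ccccc2)c2ccccc2)CC1`, 5300 nM
compound 3, `Cc1cccc2ccn(CCCCN3CCN(C(c4ccccc4)c4ccccc4)CC3)c12`, 2300 nM

In an assay on RPMI-8226 cells for antagonist activity at P2X purinoceptor 7 (Homo sapiens), read by calcium flux (on this read-out lower numbers stand for stronger inhibition and higher numbers for weaker inhibition), compound 3 stands second highest of the three numbers, with a 2.3-fold lower number from compound 2 to compound 3 (0.36 log units; beyond the scatter) and a 4.1-fold higher number from compound 1 to compound 3 (0.61 log units; beyond the scatter) around it. Compound 4, `N#Cc1ccc2c(ccn2CCCCN2CCN(C(c3ccccc3)c3ccccc3)CC2)c1`, carries 5-cyano-1H-indol-1-yl in place of 7-methyl-1H-indol-1-yl on a saturated chain carbon, four bonds along the chain from an amine nitrogen in a ring. Going by the values given here, no measured step makes this exact exchange; the three steps among compounds 1, 2 and 3 all swap the group at this same place, and each was modest, so a modest shift is expected here too, though the direction is uncertain. Compound 4 is therefore expected to give about 1500 nM in this assay, within 400 nM to 6000 nM, which means an estimated 1.5-fold lower number from compound 3 to compound 4 (0.19 log units; within the scatter).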

Compound 4, half-maximal inhibitory concentration: 3800 nM
The estimate for compound 4 lay 2.5-fold (0.40 log units) below the measured number, within the range that was stated.
By their numbers in this assay, from the lowest: compound 1; then compounds 3, 4 and 2 (each within the scatter of the next, the first and the last beyond it).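

Putting 5-cyano-1H-indol-1-yl in place of 7-methyl-1H-indol-1-yl gives a 1.7-fold higher number from compound 3 to compound 4 (0.22 log units; within the scatter), and the other methyl-bearing group gives a 1.4-fold lower number from compound 2 to compound 4 (0.14 log units; within the scatter), so the nitrile-bearing group cannot be told apart from either methyl-bearing group. The group on compound 1 remains the one that stands apart, with a 6.8-fold higher number from compound 1 to compound 4 (0.83 log units; beyond the scatter). No measurement is available that would explain these numbers. From the compounds shown here alone, whether a carboxylic acid or an amine in place of the nitrile would give a step beyond the scatter remains open.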